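A few compounds are considered here, and "the series" means these few. Any claim that something is new, unique, unknown or untested is made for them only; others in the source may bear on it.

Measured compounds:
compound 1, `COc1ccc(CNc2nc3cc(N)cc(N)c3nc2-c2ccccc2)cc1OC`: < 100000 nM
compound 2, `COc1ccc(Sc2nc3cc(N)cc(N)c3nc2-c2ccccc2)cc1`: < 100000 nM

In a functional assay on A549 cells (Homo sapiens) for inhibition, read by sulforhodamine B assay, with a stated time of 48 h (a higher number here means that more compound is tolerated, a lower number that less compound is tolerated), compound 2 gives < 100000 nM, which is a limit of the assay rather than a number. Compound 1 likewise stands only at a limit. Among the measured compounds shown here, both values shown sit at the same limit (the limit of < 100000 nM in this assay, at which 2 of the 2 values shown sit), so no step between measured compounds can be given.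

Compound 3, `Nc1cc(N)c2nc(-c3ccccc3)c(Sc3ccc(F)cc3)nc2c1`, differs from compound 2 by fluoro in place of methoxy on an aromatic carbon. With nothing measured for such a change, the step that the limit leaves unreadable from compound 2 to compound 3 is expected to stay within the scatter. Compound 3 is therefore estimated at 50000 nM, ranging from 10000 nM to 100000 nM, and may again be reported only as a limit.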

Compound 3, concentration lethal to 50% of the cells: 70800 nM
Compound 3: middle estimate off by 1.4-fold (0.15 log units), on the low side, within the range that was stated.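

The step between compound 2 and compound 3 cannot be read, because compound 2 stands only at a limit: the limit of < 100000 nM in this assay, at which 2 of the 3 values shown sit.

On these data alone, how far fluoro in place of methoxy shifts the value in this assay remains open.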